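The compounds below may be only part of what the source reports. "The series", "measured", "known", "first", "only" and "open" are said of these compounds alone.

Measured in a functional assay on HepG2 cells (Homo sapiens) for antiproliferative activity, read by MTT assay, with a stated time of 72 h; on this read-out lower numbers stand for stronger inhibition and higher numbers for weaker inhibition:
- Compound 1 `O=C1O/C(=C\Cn2cc(-c3ccc(Br)cc3)nn2)C(OCc2ccccc2)=C1OCc1ccccc1`: > 100000 nM
- Compound 2 `Cc1ccc(-c2cn(C/C=C3\OC(=O)C(OCc4ccccc4)=C3OCc3ccccc3)nn2)cc1`: > 100000 nM
- Compound 3 `O=C1O[C@H]([C@@H](O)Cn2cc(-c3cccc(O)c3)nn2)C(OCc2ccccc2)=C1OCc1ccccc1`: 62700 nM

Compound 1 gives > 100000 nM, which is a limit and not a number. Compound 2 gives > 100000 nM, again a limit. Compound 3 is therefore the only one of the series with an actual number, 62700 nM.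

Compound 4 `CCCCCc1ccc(-c2cn(C[C@H](O)[C@H]3OC(=O)C(OCc4ccccc4)=C3OCc3ccccc3)nn2)cc1` has not yet been measured in this assay. Its change from compound 3 is 4-pentylphenyl in place of 3-hydroxyphenyl on an aromatic carbon of a five-membered aromatic ring with 3 nitrogen.

For the measured compounds named here, the only measured step is a step that the two limits leave unreadable from compound 1 to compound 2. It offers no size to carry over, and it involves neither of the two groups exchanged here. No direction is therefore supported by the data, and no step beyond the usual scatter is expected, though with wide uncertainty. The expected change is a 1.6-fold lower number from compound 3 to compound 4 (0.20 log units; within the scatter). Compound 4 is estimated at 40000 nM, with an expected range from 8000 nM to 100000 nM.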

Compound 4, half-maximal inhibitory concentration: 7460 nM
Estimate against measurement, compound 4: 5.4-fold (0.73 log units) above; measured number below the stated range.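

For the compounds shown here, the exchange of 3-hydroxyphenyl for 4-pentylphenyl gives the first step in this assay whose size can be read, an 8.4-fold lower number from compound 3 to compound 4 (0.92 log units; beyond the scatter). Going by these compounds alone, the only earlier step cannot be read, as both of its compounds rest on a limit of the assay: the limit of > 100000 nM in this assay, at which 2 of the 4 values shown sit. On this aromatic carbon of the five-membered aromatic ring with 3 nitrogen, the group on the triazole-bearing side can thus shift the read-out beyond the scatter, and the entering group does so with 0 hydrogen-bond donors and 0 hydrogen-bond acceptors.

The change removes the hydroxy group, adds the pentyl chain and alters the substitution of the phenyl ring all at once, and the compounds shown do not separate these parts. As far as these compounds go, how an amine, a carboxylic acid or a longer chain in place of the pentyl chain would read in this assay remains open.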